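The compounds below may be only part of what the source reports. "The series", "measured", "known", "first", "only" and "open" are said of these compounds alone.

Values in a functional assay on HeLa cells (Homo sapiens) for inhibition, read by MTT assay, with a stated time of 48 h; on this read-out lower numbers stand for stronger inhibition and higher numbers for weaker inhibition:
- compound 1 `O=C(CC(c1ccc(F)cc1)C(C(=O)Nc1ccccn1)C(=O)Nc1ccccn1)c1ccccc1`: 20800 nM
- compound 2 `O=C(CC(c1ccc(F)cc1)C(C(=O)Nc1ccccn1)C(=O)Nc1ccccn1)c1ccc(F)cc1`: 25500 nM
- compound 3 `O=C(CC(c1ccc(Cl)cc1)C(C(=O)Nc1ccccn1)C(=O)Nc1ccccn1)c1ccc2ccccc2c1`: "not active" (no number reported)

Only compound 1 and compound 2 carry numbers, and these sit within the scatter of each other. Among the compounds with values here, compound 1 therefore stands level with its one numeric neighbour.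

Next in the series is compound 4 `COc1ccc(C(CC(=O)c2ccccc2)C(C(=O)Nc2ccccn2)C(=O)Nc2ccccn2)cc1`, where 4-fluorophenyl becomes 4-methoxyphenyl: methoxy in place of fluoro on an aromatic carbon. This is methoxy in place of fluoro on an aromatic carbon, para to a large group.

Within the data shown here, no measured step makes this exchange. The nearest evidence is a 1.2-fold higher number from compound 1 to compound 2 (0.09 log units; within the scatter), a fluoro in place of hydrogen elsewhere in the molecule, and it lies within the scatter. Compound 3 differs from compound 1 in more than one place, so it offers no clean comparison. With so little evidence, no direction is favoured in this assay, and no step beyond the scatter is expected. The estimated step is a 1.1-fold higher number from compound 1 to compound 4 (0.02 log units; within the scatter).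

For compound 4 the estimate is 22000 nM, with an expected range from 9000 nM to 55000 nM.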

Compound 4, half-maximal inhibitory concentration: "not active" (no number reported)
No number was reported for compound 4; there is nothing to compare the estimate with.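

Within the data shown here, compound 4 is recorded as not active with no number, and no step from compound 1 can be read. No available evidence bears on this result. The compounds shown leave open how 4-methoxyphenyl in place of 4-fluorophenyl changes inhibition in numerical terms.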